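The source may hold more compounds than are shown below. What is called first, only, known or untested is meant among the compounds shown, and "the series" means these compounds.

Measured compounds in an assay on isolated protein (strain albino) for antagonist activity at Voltage-dependent L-type calcium channel subunit alpha-1C (Cavia porcellus); a lower number here means a stronger inhibitor, a higher number a weaker inhibitor:
compound 1 `COC(=O)C1=C(C)NC(C)=C(C(=O)OCc2ccccc2)C1c1cnc(SC)n1Nc1ccccc1` gives 2.21 nM
compound 2 `CSc1ncc(C2C(C(=O)OC(C)C)=C(C)NC(C)=C2C(=O)OC(C)(C)C)n1Nc1ccccc1` gives 68.2 nM

Compound 2 stands at the higher of the two numbers in this assay; its nearest neighbour, compound 1, sits a long way lower, a gap well beyond the usual scatter. The two compounds differ at more than one position, so no single step can be read from them; the values alone show that compound 1 is the stronger inhibitor of the pair.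

Compound 3 `CSc1ncc(C2C(C(=O)OCc3ccccc3)=C(C)NC(C)=C2C(=O)OC(C)C)n1Nc1ccccc1` is not yet measured. It arises from compound 2 by one change: benzyl in place of tert-butyl on an oxygen next to a carbonyl group. Among the measured compounds shown here, no measured pair isolates this exact exchange, so the size of the step is open. The expectation is a lowering of the number for compound 3, of moderate size, because compound 1 also carries a benzyl ester and gives 2.21 nM in this assay. The estimated step from compound 2 to compound 3 is a 6.8-fold lower number from compound 2 to compound 3 (0.83 log units; beyond the scatter). For compound 3 the expected value is 10 nM, with a plausible range from 2.5 nM to 40 nM.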

Compound 3, half-maximal inhibitory concentration: 7.24 nM
Compound 3: the middle estimate sits 1.4-fold (0.14 log units) above what was measured; low and high end bracket the measured number.
By their numbers in this assay, from the lowest: compound 1; then compound 3; then compound 2.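

In this assay, among the compounds shown here, the exchange of tert-butyl for benzyl on an oxygen next to a carbonyl group gives a 9.4-fold lower number from compound 2 to compound 3 (0.97 log units; beyond the scatter) and is the first single-place reading at this position, with the isopropyl ester on the other side of the shared core held constant. With the benzyl ester held constant instead, the exchange of methyl for isopropyl on an oxygen next to a carbonyl group gives a 3.3-fold higher number from compound 1 to compound 3 (0.52 log units; beyond the scatter) as a second step beyond the scatter, so the number responds to the group on either ester oxygen, and compound 1 remains the strongest inhibitor of the three. Nothing shown accounts for either step.

As far as these compounds go, each exchange rests on a single pair, so it remains open whether benzyl in place of tert-butyl would give a similar step with a partner ester other than isopropyl, or whether isopropyl in place of methyl would do so with a partner other than benzyl. The compounds shown also leave open how a longer chain such as n-hexyl, or an ester chain ending in an amine, would read at either ester oxygen.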